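The compounds below may be only part of what the source reports. "The series", "measured", "known", "first", "only" and "open" are said of these compounds alone.

Measured compounds:
compound 1 `COc1cc2c(Oc3c(F)cc(NC(=O)NN4C(=O)CSC4c4c(F)cccc4F)cc3F)ccnc2cc1OCCCN1CCC(C)CC1`: 970 nM
compound 2 `COc1cc2c(Oc3c(F)cc(NC(=O)NN4C(=O)CSC4c4c(F)cccc4F)cc3F)ccnc2cc1OCCCN1C[C@H]2CCCC[C@H]2C1`: 1930 nM
compound 3 `COc1cc2c(Oc3c(F)cc(NC(=O)NN4C(=O)CCSC4c4c(F)cccc4F)cc3F)ccnc2cc1OCCCN1CCC(C)CC1`: 1630 nM

In a functional assay on A549 cells (Homo sapiens) for antiproliferative activity, read by MTT assay, with a stated time of 72 h (a higher number here means a weaker inhibitor, a lower number a stronger inhibitor), compound 1 gives 970 nM. Compound 2 differs from compound 1 in one place, (a group of 9 heavy atoms (8 carbon, 1 nitrogen; one five-membered non-aromatic ring with 1 hetero atom, one six-membered non-aromatic ring of carbon only) in place of a group of 7 heavy atoms (6 carbon, 1 nitrogen; one six-membered non-aromatic ring with 1 hetero atom), on a saturated chain carbon, three bonds along the chain from an oxygen on an aromatic ring), and this change made a 2.0-fold higher number from compound 1 to compound 2 (0.30 log units; within the scatter). Compound 3 is built on a different core; how the two cores differ is not broken down here. In this assay compound 3 gives 1630 nM, a number that sits close to those of compound 1 and compound 2.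

Compound 4 `COc1cc2c(Oc3c(F)cc(NC(=O)NN4C(=O)CCSC4c4c(F)cccc4F)cc3F)ccnc2cc1OCCCN1C[C@H]2CCCC[C@H]2C1` has not yet been measured. It stands to compound 3 as compound 2 stands to compound 1: a group of 9 heavy atoms (8 carbon, 1 nitrogen; one five-membered non-aromatic ring with 1 hetero atom, one six-membered non-aromatic ring of carbon only) in place of a group of 7 heavy atoms (6 carbon, 1 nitrogen; one six-membered non-aromatic ring with 1 hetero atom), on a saturated chain carbon, three bonds along the chain from an oxygen on an aromatic ring. The place of the change is the same in both pairs, so it is the same change, and it occurs two times among these compounds.

Going by the values given here, for compound 4 the step of a 2.0-fold higher number from compound 3 to compound 4 (0.29 log units; within the scatter) is expected to resemble the earlier one, because a 2.0-fold higher number from compound 1 to compound 2 (0.30 log units; within the scatter) is the only guide to this change. Compound 4 is therefore estimated at 3200 nM, with a likely range from 1500 nM to 7000 nM.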

Compound 4, half-maximal inhibitory concentration: 3610 nM
Compound 4: the middle estimate sits 1.1-fold (0.05 log units) below what was measured, and the stated range covers the measured number.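

In this assay, putting the two-ring group in place of the 4-methylpiperidin-1-yl group on the core of compound 3 gave a 2.2-fold higher number from compound 3 to compound 4 (0.35 log units; beyond the scatter), a modest step that lies just beyond the usual scatter. The same change on the core of compound 1 gave a step of very nearly the same size, so in this small set it carried from one core to the other with no visible difference: the same change on two cores in this assay, a 2.0-fold higher number (0.30 log units; within the scatter) from compound 1 to compound 2 and a 2.2-fold higher number (0.35 log units; beyond the scatter) from compound 3 to compound 4, 1.1-fold (0.05 log units) apart, within the scatter of two such steps. Going by these compounds alone, this shows only that the change kept its size across these two cores in one cell assay, since two pairs cannot establish a rule for other cores, and the numbers do not explain why the two-ring group goes with a higher number.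

The compounds shown leave open whether the step would hold for other amines at the end of the chain, such as morpholine or an open-chain dimethylamine, or on a longer chain. They also leave open whether either stereoisomer of the two-ring group would behave differently from the one shown.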